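Ester and aryl swaps in a cytotoxicity screen

The source may report more compounds than this note shows. Statements on the series, on what has been measured and on what is new or still open speak of the compounds shown alone.

In an ADME assay on HEK293 cells (Homo sapiens) for cytotoxicity, read by CellTiter-Glo and resazurin assay, with a stated time of 72 h (a higher number here means that more compound is needed for the effect, a lower number that less compound is needed), compound 1 `CC(C)N(Cc1cccc(OCCCCCC(=O)O)c1)C(=O)c1ccc(-c2ccc3cc[nH]c3c2)cc1` gives only a limit of the assay, > 26000 nM. Compound 2 `COc1cc(OC)cc(-c2ccc(C(=O)N(Cc3cccc(OCCCCCC(=O)O)c3)C(C)C)cc2)c1` also gives only a limit, > 26000 nM. Compound 3 `CCOC(=O)CCCCCOc1cccc(CN(C(=O)c2ccc(-c3ccc4cc[nH]c4c3)cc2)C(C)C)c1` likewise gives only a limit, > 26000 nM. Compound 2 differs from compound 1 by 3,5-dimethoxyphenyl in place of 1H-indol-6-yl on an aromatic carbon, and the step is a step that the two limits leave unreadable from compound 1 to compound 2. Compound 3 differs from compound 1 by ethyl in place of hydrogen on an oxygen next to a carbonyl group, with the step that the two limits leave unreadable from compound 1 to compound 3. All three values share (the limit of > 26000 nM in this assay, at which 3 of the 3 values shown sit). Compound 4 `CCOC(=O)CCCCCOc1cccc(CN(C(=O)c2ccc(-c3cc(OC)cc(OC)c3)cc2)C(C)C)c1` is not yet measured; it differs from compound 3 by 3,5-dimethoxyphenyl in place of 1H-indol-6-yl on an aromatic carbon, the same change already seen between compound 1 and compound 2, at the same place. Because that change gave a step that the two limits leave unreadable from compound 1 to compound 2, the expected step in this assay is a step that the limit leaves unreadable from compound 3 to compound 4. Compound 4 is expected at 30000 nM, most likely again a limit.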

Compound 4, half-maximal effective concentration: > 26000 nM
Compound 4 gave a limit, no number (the forecaster's own chance of this, stated with the estimate: 85%); the middle value lies beyond the limit too.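

No step can be read from compound 2 to compound 4 or from compound 3 to compound 4, because all these values sit at one limit: the limit of > 26000 nM in this assay, at which 4 of the 4 values shown sit.

The compounds shown leave open at what concentration any of them would reach its half-maximal effect in this assay, and whether either change alters that concentration.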